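Nitro for Methoxy: Compound 3 Against an Inactive Pair

The source may hold more compounds than are shown below. What is called first, only, known or untested is meant among the compounds shown, and "the series" means these compounds.

Compound 1 `COc1ccc(-c2cc(-c3ccc(OC)cc3)on2)cc1` stands at the limit of an ADME assay on HMEC-1 cells (Homo sapiens) for antiproliferative activity, read by cell counting, with a stated time of 5 days; on this read-out higher numbers stand for weaker inhibition and lower numbers for stronger inhibition: in this assay compound 1 gives > 100000 nM, a limit and not a number. Compound 2 `COc1ccc(-c2noc(-c3ccc(OC)cc3)c2C)cc1` likewise gives > 100000 nM in this assay, again a limit. The step that the two limits leave unreadable from compound 1 to compound 2 is therefore unreadable, both values sharing (the limit of > 100000 nM in this assay, at which 2 of the 2 values shown sit). Compound 3 `COc1ccc(-c2cc(-c3ccc([N+](=O)[O-])cc3)on2)cc1` differs from compound 1 by nitro in place of methoxy on an aromatic carbon. Among the measured compounds shown here, no measured step bears on this change, and none in this assay has yielded a readable size, so the series gives no direction. For compound 3 the expected step is a number no higher from compound 1 to compound 3 (the limit leaves the size open). Compound 3 is estimated at 100000 nM, between 30000 nM and 300000 nM, with a limit again the likeliest outcome.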

Compound 3, half-maximal inhibitory concentration: > 100000 nM
Compound 3: a limit, no number; the forecaster's own chance of this, stated with the estimate: 70%; the middle value sits exactly at the limit.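

Among the compounds shown here, compound 3 gives > 100000 nM in this assay, a limit and not a number, so no new step from compound 1 can be read. The compounds shown leave open whether any change to the shared core gives a readable value: the limit of > 100000 nM in this assay, at which 3 of the 3 values shown sit.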